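Methyl to chloro on the aryl ring of the oxadiazole series

The compounds below may be only part of what the source reports. "The series", "measured", "known", "first", "only" and "open" are said of these compounds alone.

Compound 1 `Cc1cccc(-c2noc(C3CN(S(=O)(=O)c4cccc(C)c4)C3)n2)c1` carries a sulfonyl on the azetidine nitrogen. In an assay on HEK293 cells for positive allosteric modulation of metabotropic glutamate receptor 5 (Homo sapiens), read by FLIPR (a higher number here means that more compound is needed for the effect, a lower number that less compound is needed), compound 1 returns only a limit of the assay, > 10000 nM. Compound 2 `Cc1cccc(S(=O)(=O)N2CC(c3nc(-c4cccc(Cl)c4)no3)C2)c1` differs from it by chloro in place of methyl on an aromatic carbon. In this assay compound 2 also returns a limit, > 10000 nM. The step that the two limits leave unreadable from compound 1 to compound 2 therefore cannot be sized, because the limit of > 10000 nM in this assay, at which 2 of the 3 values shown sit, hides both ends of it.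

Going by the values given here, compound 3 `Cc1cccc(-c2noc(C3CN(C(=O)C4CCC(C(F)(F)F)CC4)C3)n2)c1` replaces the sulfonyl with an amide of a trifluoromethyl-substituted cyclohexane; in this assay compound 3 gives 1000 nM, the only number in the set. The difference between the core of compound 1 and the core of compound 3 is not broken down here.

Compound 4 `O=C(C1CCC(C(F)(F)F)CC1)N1CC(c2nc(-c3cccc(Cl)c3)no2)C1` is not yet measured. It differs from compound 3 by chloro in place of methyl on an aromatic carbon, the same change as between compound 1 and compound 2, at the same place. Since that earlier step yields no readable size, nothing measured says how large the step should be. A modest step, a 1.2-fold higher number from compound 3 to compound 4 (0.08 log units; within the scatter), is expected for compound 4. Compound 4 is estimated at 1200 nM, with a range from 400 nM to 4000 nM.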

Compound 4, half-maximal effective concentration: 1000 nM
Compound 4: the middle estimate sits 1.2-fold (0.08 log units) above what was measured; the range from low to high includes it.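

Carried onto the core of compound 3, the change from 3-methylphenyl to 3-chlorophenyl shows in this assay no change at the digits printed from compound 3 to compound 4 (within the scatter), so on this amide core the chloro takes the place of the methyl with no readable shift. This is one pair on one core, and it gives no general rule for the change across the series. Whether the sulfonyl core responds in the same way cannot be said, and no comparison between the two cores can be drawn, because the step on that core cannot be read with both of its compounds resting on a limit of the assay: the limit of > 10000 nM in this assay, at which 2 of the 4 values shown sit.

The compounds shown leave open how a methoxy group or a nitrile on the same aromatic carbon would read in this assay, as only methyl and chloro appear there. Also open, going by these compounds, is how an amine or a carboxylic acid in place of the trifluoromethyl on the cyclohexane would read in this assay.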